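Oxopurine glycinamide amino acid series: tail flick notes

The compounds below may be only part of what the source reports. "The series", "measured", "known", "first", "only" and "open" are said of these compounds alone.

Measured compounds:
compound 1, `C[C@@H](O)[C@H](NC(=O)CN(c1nc(Cl)nc2[nH]cnc12)C1CC1)C(=O)O`: 30.1%
compound 2, `CC(C)[C@H](NC(=O)CN(c1ncnc2c1ncn2C1CCCCO1)C1CC1)C(=O)OCc1ccccc1`: 34.9%
compound 3, `CC(C)[C@H](NC(=O)CN(c1nc(Cl)nc2[nH]cnc12)C1CC1)C(=O)OCc1ccccc1`: 55.5%

In a functional assay on the whole organism (Tail, strain ICR) with Mus musculus as the target, in the tail flick test, with a stated time of 60 min, at a dose of 25 umol/kg by the oral route (a lower number here means a weaker effect, a higher number a stronger effect of the compound at the dose given), compound 1 gives 30.1%, the lowest of the three numbers. The gap to compound 2 lies within the scatter, so the two cannot be ordered against each other. Compound 3 stands beyond the scatter above compound 1; both carry the same chlorinated core, and compound 3 differs in having the benzyl ester and the isopropyl side chain in place of the free acid and the 1-hydroxyethyl side chain of compound 1.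

Compound 4, `O=C(O)C[C@H](NC(=O)CN(c1nc(Cl)nc2[nH]cnc12)C1CC1)C(=O)O`, is the next member to be tested. It differs from compound 1 by carboxymethyl in place of 1-hydroxyethyl on a saturated chain carbon bound to an amide-type nitrogen and a carbonyl carbon. Going by the values given here, no measured pair shows this particular exchange, so its effect is untested. Compound 4 keeps the free acid and the chlorinated core of compound 1, and only the side chain changes. In this assay the step is expected to be small, not beyond the scatter, or slightly downward, because compound 1 already gives 30.1% at the low end of the series. The expected step is a number 5.1 percentage points lower from compound 1 to compound 4 (within the scatter). Compound 4 is thus estimated at 25%, with a range from 10% to 42%.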

Compound 4, a percentage reported as activity, at one dose (the size of the read-out at that dose, not a potency): 38.9%
Beside the measured number, compound 4's estimate is 13.9 percentage points below it; measured number inside the range.
By their numbers in this assay, from the lowest: compounds 1, 2 and 4 (each within the scatter of the next); then compound 3.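

In this assay, carboxymethyl in place of 1-hydroxyethyl on a saturated chain carbon bound to an amide-type nitrogen and a carbonyl carbon gives a number 8.8 percentage points higher from compound 1 to compound 4 (within the scatter). Going by these compounds alone, this is the first step that isolates the side chain, since the earlier compounds differ from one another in more than one place. Within the data shown here, with the free acid and the shared core held constant, exchanging these two side chains therefore gives no step that can be told from the scatter. No measurement at hand explains this result.

Open, from the compounds shown here alone, is whether an amine or a longer chain at this position would give a step beyond the scatter. Also open, going by these compounds, is whether the exchange from 1-hydroxyethyl to carboxymethyl reads the same when the free acid is replaced by a benzyl ester.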